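The compounds below may be only part of what the source reports. "The series", "measured", "known", "first", "only" and "open" are said of these compounds alone.

Two compounds share one core and differ only in a single group. Compound 1, `COc1ccc(Nc2nc3ccccc3nc2S(=O)(=O)c2ccc(C)cc2)cc1`, gives in a functional assay on A549 cells (Homo sapiens) for cytotoxicity, read by MTT assay, with a stated time of 72 h (a higher number here means a weaker inhibitor, a lower number a stronger inhibitor), only a limit, > 50000 nM, and not a measured number. Compound 2, `Cc1ccc(S(=O)(=O)c2nc3ccccc3nc2Nc2ccc(F)cc2)cc1`, gives in this assay a measured value of 39200 nM. The step of an at least 1.2-fold lower number from compound 1 to compound 2 (0.10 log units; that floor lies within the scatter) follows from these two results, and its floor lies within the scatter of repeated measurements; because one of the two values is a limit (the limit of > 50000 nM in this assay, at which 1 of the 2 values shown sits), the true size of this step is not known. Among the results shown, compound 2 holds the only measured number, the other result being a limit.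

Compound 3, `O=S(=O)(c1ccc(Br)cc1)c1nc2ccccc2nc1Nc1ccc(F)cc1`, differs from compound 2 by bromo in place of methyl on an aromatic carbon. Going by the values given here, no measured step concerns this exchange of methyl for bromo; the single measured step, an at least 1.2-fold lower number from compound 1 to compound 2 (0.10 log units; that floor lies within the scatter), concerns a different group and is itself no larger than the scatter. Nothing here points to a change beyond the scatter in this assay, in either direction. Compound 3 is therefore expected to give about 35000 nM, with a plausible range from 10000 nM to 100000 nM. The step of a 1.1-fold lower number from compound 2 to compound 3 (0.05 log units; within the scatter) is thus estimated to stay within the scatter.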

Compound 3, half-maximal inhibitory concentration: 4360 nM
Compound 3: the middle estimate sits 8.0-fold (0.90 log units) above what was measured, and the stated range ends above it.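

Putting bromo in place of methyl, which turns 4-methylphenyl into 4-bromophenyl, gives a 9.0-fold lower number from compound 2 to compound 3 (0.95 log units; beyond the scatter) in this assay. This is the first step shown that clearly passes the scatter, and it marks this place on the ring, para to a large group, as one where a single exchange can move the number, which the earlier step on a different group could not show. The exchange is small by simple count, one heavy atom for one heavy atom with no hydrogen-bond donors, acceptors or net charge on either side, and nothing given here tells what lies behind the change.

As far as these compounds go, whether other groups at this same place, such as chloro, an amine or a carboxylic acid, would lower the number as far, or raise it instead, remains open. Also open, from the compounds shown here alone, is whether bromo would have a similar effect with methoxy in place of fluoro, as in compound 1, which gives > 50000 nM in this assay, a limit and not a number.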